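The compounds below may be only part of what the source reports. "The series", "measured", "known", "first", "only" and "open" are said of these compounds alone.

In a functional assay with Oryctolagus cuniculus as the target (on this read-out lower numbers stand for stronger inhibition and higher numbers for weaker inhibition), compound 1 `COc1ccc(-c2nc(C(=O)N3CCCCC3)sc2-c2ccc(OC)cc2)cc1` gives > 1000 nM, which is a limit and not a number. Compound 2 `COc1ccc(-c2nc(/C=C/C(=O)O)sc2-c2ccc(OC)cc2)cc1` gives > 100 nM, which is also only a limit. Among the compounds with values here, the one measured step, a step that the two limits leave unreadable from compound 1 to compound 2, therefore has no readable size and shows no direction. Compound 3 `COc1ccc(-c2nc(C3=CCN(C)CC3)sc2-c2ccc(OC)cc2)cc1` differs from compound 2 at a single place on the shared core: a group of 7 heavy atoms (6 carbon, 1 nitrogen; one six-membered non-aromatic ring with 1 hetero atom) in place of a group of 5 heavy atoms (3 carbon, 2 oxygen; no ring), on an aromatic carbon. With both neighbours known only through limits, compound 3 is expected to remain in the same weak region. The expected step, a step that the limit leaves unreadable from compound 2 to compound 3, is only a rough estimate. For compound 3 the estimated value is 1000 nM, within an expected range of 200 nM to 5000 nM.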

Compound 3, half-maximal inhibitory concentration: < 10 nM
Compound 3: a limit, no number; the forecaster's own chance of this, stated with the estimate: 60%; middle value at least 100-fold (2.00 log units) away from the limit.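

This position on the shared core can carry strong activity in this assay: the six-membered non-aromatic ring in place of 2-carboxyethenyl gives an at least 10-fold lower number from compound 2 to compound 3 (1.00 log units; beyond the scatter). A six-membered non-aromatic ring with 1 hetero atom also sits in the weaker partner of an at least 100-fold lower number from compound 1 to compound 3 (2.00 log units; beyond the scatter), so such a ring alone is not enough. Compound 3 gives a limit, not a number, so both steps show only minimum sizes: the limit of < 10 nM in this assay, at which 1 of the 3 values shown sits.

Going by these compounds, it remains open whether the ring nitrogen or the ring itself matters more. A cyclohexenyl group, with carbon in place of that nitrogen, or an open-chain amine would separate the two.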